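Hexyloxy to Hexylsulfanyl on a Quinuclidinyl Pyrazine

The compounds below may be only part of what the source reports. "The series", "measured", "known", "first", "only" and "open" are said of these compounds alone.

Measured so far:
compound 1 `Clc1nccnc1C1CN2CCC1CC2` gives 13%
compound 2 `CCCCCCOc1nccnc1C1CN2CCC1CC2` gives 40%

In a functional assay on A9L-m1 cells with A9 (Mus musculus) as the target (a lower number here means a smaller maximal response, a higher number a larger maximal response), compound 2 stands highest of the two numbers measured; its nearest neighbour is compound 1, and the step of a number 27 percentage points higher from compound 1 to compound 2 (beyond the scatter) came with hexyloxy in place of chloro on an aromatic carbon. Compound 3 `CCCCCCSc1nccnc1C1CN2CCC1CC2` has not yet been measured. It differs from compound 2 in one place: hexylsulfanyl in place of hexyloxy on an aromatic carbon. Among the compounds with values here, the only measured step swaps a chloro for a hexyloxy, so it does not bear directly on exchanging the oxygen of the hexyloxy for the sulfur of the hexylsulfanyl; the chain length stays the same. Within the data shown here, with no step of this kind to lean on, the expected change from compound 2 to compound 3 in this assay is no change at the digits printed from compound 2 to compound 3 (within the scatter), none beyond the scatter. For compound 3 the estimated value is therefore 40%, with a range from 22% to 60%.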

Compound 3, largest response reached (reported as maximum), in percent of the reference or control that the assay uses: 16%
The estimate for compound 3 lay 24 percentage points above the measured number; measured number below the stated range.
By their numbers in this assay, from the lowest: compounds 1 and 3 (each within the scatter of the next); then compound 2.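

In this assay, the link between the hexyl chain and the aromatic carbon proved to matter at this position: with the chain unchanged, sulfur in place of oxygen gave a number 24 percentage points lower from compound 2 to compound 3 (beyond the scatter). The earlier step could not show whether a hexyl chain alone went with the larger maximal response, and this one shows that it does not, since hexylsulfanyl and chloro do not separate, with a number 3 percentage points higher from compound 1 to compound 3 (within the scatter). Nothing at hand explains why the two linking atoms part in this way.

The compounds shown leave open whether the gap between oxygen and sulfur links holds for a shorter or longer chain. Also open, from the compounds shown here alone, is how an amine link, as in hexylamino, would compare in the same place in this assay.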